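An ester tail gives way to an allyl ether

The source may report more compounds than this note shows. Statements on the series, on what has been measured and on what is new or still open speak of the compounds shown alone.

Values in a functional assay on BV-2 cells (Mus musculus) for inhibition, read by Griess assay, with a stated time of 24 h; a higher number here means a weaker inhibitor, a lower number a stronger inhibitor:
Compound 1 `C=CCc1ccc(OC)c(-c2cc(CO)on2)c1` gives > 200000 nM, a limit of the assay
Compound 2 `C=CCOCc1cc(-c2cc(Br)ccc2OC)no1` gives 90400 nM
Compound 3 `C=CCc1ccc(OC)c(-c2cc(COCC(=O)OCC)on2)c1` gives 25900 nM

Compound 3 holds the lowest number shown, and compound 2 stands higher. Compound 4 `C=CCOCc1cc(-c2cc(CC=C)ccc2OC)no1` departs from compound 3 by one change (vinyl in place of ethoxycarbonyl on a saturated chain carbon bound to an oxygen on a saturated carbon), vinyl in place of ethoxycarbonyl on a saturated chain carbon bound to an oxygen on a saturated carbon. The measured step bearing on this oxygen is an at least 7.7-fold lower number from compound 1 to compound 3 (0.88 log units; beyond the scatter). Compound 2 also carries (allyloxy)methyl, though its core differs elsewhere, and it gives 90400 nM. A modest rise is therefore expected in this assay, not a large one. The expected change is a 2.1-fold higher number from compound 3 to compound 4 (0.33 log units; beyond the scatter). For compound 4 the estimated value is 55000 nM, within an expected range of 18000 nM to 160000 nM.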

Compound 4, half-maximal inhibitory concentration: 28700 nM
Compound 4: the middle estimate sits 1.9-fold (0.28 log units) above what was measured; measured number inside the range.
By their numbers in this assay, from the lowest: compounds 3 and 4 (each within the scatter of the next); then compound 2. At a limit, above all of these: compound 1.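

In this assay, the ester tail and the allyl ether read alike at this position, with a 1.1-fold higher number from compound 3 to compound 4 (0.04 log units; within the scatter). The other site matters more: allyl in place of bromo on an aromatic carbon gives a 3.1-fold lower number from compound 2 to compound 4 (0.50 log units; beyond the scatter). Allyl in place of hydrogen on the oxygen gives an at least 6.9-fold lower number from compound 1 to compound 4 (0.84 log units; beyond the scatter), a bound only, as compound 1 stands at a limit: the limit of > 200000 nM in this assay, at which 1 of the 4 values shown sits.

The compounds shown leave open whether a carboxylic acid, an amine or a longer chain on this oxygen would shift the number at all.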